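The source may hold more compounds than are shown below. What is called first, only, known or untested is meant among the compounds shown, and "the series" means these compounds.

The measured compounds:
Compound 1 `OC[C@H]1O[C@@H](n2cc(F)c3c(-c4ccccc4)ncnc32)[C@H](O)[C@@H]1O` gives > 10000 nM in a functional assay on HCT-116 cells (Homo sapiens), read by sulforhodamine B assay, with a stated time of 5 days (a lower number here means a stronger inhibitor of growth, a higher number a weaker inhibitor of growth), which is a limit of the assay rather than a number.
Compound 2 `OC[C@H]1O[C@@H](n2cc(F)c3c(-c4nccs4)ncnc32)[C@H](O)[C@@H]1O` gives 1300 nM in this assay.
Compound 3 `OC[C@H]1O[C@@H](n2cc(F)c3c(-c4ccc[nH]4)ncnc32)[C@H](O)[C@@H]1O` gives 450 nM in this assay.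

Compound 1 thus stands at the limit of > 10000 nM in this assay, at which 1 of the 3 values shown sits, so every step away from it is known only as a minimum size. Compound 4 `OC[C@H]1O[C@@H](n2cc(F)c3c(-c4c[nH]cn4)ncnc32)[C@H](O)[C@@H]1O` differs from compound 1 by 1H-imidazol-4-yl in place of phenyl on an aromatic carbon. For the measured compounds named here, two measured steps bear on this change, each exchanging phenyl for a five-membered aromatic ring: an at least 7.6-fold lower number from compound 1 to compound 2 (0.88 log units; beyond the scatter) and an at least 22-fold lower number from compound 1 to compound 3 (1.34 log units; beyond the scatter), both beyond the scatter. Between those two rings, a 2.9-fold lower number from compound 2 to compound 3 (0.46 log units; beyond the scatter). A downward step of comparable size is therefore expected, an at least 12-fold lower number from compound 1 to compound 4 (1.09 log units; beyond the scatter). Compound 4 is estimated at 800 nM, likely between 200 nM and 4000 nM.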

Compound 4, concentration for 50% growth inhibition: > 10000 nM
Compound 4: a limit, no number; the forecaster's own chance of this, stated with the estimate: 10%; at least 12-fold (1.09 log units) between middle value and limit.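

A five-membered aromatic ring on this carbon does not by itself bring growth inhibition: 1H-imidazol-4-yl in place of 1H-pyrrol-2-yl gives an at least 22-fold higher number from compound 3 to compound 4 (1.34 log units; beyond the scatter), and in place of 1,3-thiazol-2-yl it gives an at least 7.6-fold higher number from compound 2 to compound 4 (0.88 log units; beyond the scatter). Among the compounds shown, the identity of the ring therefore matters, not just the loss of phenyl. Compound 1 and compound 4 both rest at a limit, so the step between them cannot be read: the limit of > 10000 nM in this assay, at which 2 of the 4 values shown sit.

As far as these compounds go, how a furan-2-yl ring or a simple amine on this same carbon would behave remains open.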